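A few compounds are considered here, and "the series" means these few. Any claim that something is new, unique, unknown or untested is made for them only; others in the source may bear on it.

Compound 1 `CC(C)c1nc(C(=O)NC2CCN(CC3(O)CCOCC3)CC2)c2ccccn12` gives 72% in a functional assay on CHO cells for agonist activity at 5-hydroxytryptamine receptor 4 (Homo sapiens), read by a luciferase reporter and cAMP accumulation, with a stated time of 4 h; a higher number here means a larger maximal response, a lower number a smaller maximal response. Compound 2 `CC(C)c1nc(C(=O)NC2CCN(CC(C)(C)O)CC2)c2ccccn12` gives 80% in this assay.

Compound 2 stands with the higher of the two numbers, though the step of a number 8 percentage points higher from compound 1 to compound 2 (within the scatter) lies within the scatter, so the two compounds cannot be told apart on these data. Compound 3 `COCC(C)(C)CN1CCC(NC(=O)c2nc(C(C)C)n3ccccc23)CC1` is not yet measured. It differs from compound 2 as follows: methoxymethyl in place of hydroxy on a saturated chain carbon bound to three saturated chain carbons. Going by the values given here, no measured step changes this part of the molecule; the only step seen, a number 8 percentage points higher from compound 1 to compound 2 (within the scatter), concerns a different group on the same chain and is within the scatter. A change at this place therefore has no direct guide here, and the expected step is a number 4 percentage points lower from compound 2 to compound 3 (within the scatter), none beyond the scatter. Compound 3 is estimated to reach 76% in this assay, with a likely range from 55% to 95%.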

Compound 3, largest response reached (Emax), in percent of the reference or control that the assay uses: 74%
For compound 3 the middle estimate is 2 percentage points above the measured one; the measured number falls inside the stated range.
By their numbers in this assay, from the lowest: compounds 1, 3 and 2 (each within the scatter of the next).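

Putting methoxymethyl in place of hydroxy on a saturated chain carbon bound to three saturated chain carbons gives a number 6 percentage points lower from compound 2 to compound 3 (within the scatter) in this assay, so on these data the two compounds cannot be told apart, even though the count of hydrogen-bond donors in the group goes from 1 to 0. Measured against the other compound, the larger change gives a number 2 percentage points higher from compound 1 to compound 3 (within the scatter), and so this pair cannot be told apart either. No measured evidence here bears on the cause of this result.

The compounds shown leave open whether an amine, a carboxylic acid or a longer chain at this place would keep the maximal response at this level. They also leave open whether any change at this place can produce a step beyond the scatter.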